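Replacing the 4-Fluorophenyl with Furan-2-yl: Cytotoxicity Outlook

A few compounds are considered here, and "the series" means these few. Any claim that something is new, unique, unknown or untested is made for them only; others in the source may bear on it.

Compounds measured so far:
compound 1 `O=C(Nn1c(-c2cccc([N+](=O)[O-])c2)nc2c(-c3ccc(Cl)cc3)n[nH]c2c1=O)c1cccnc1` — 19.7%
compound 2 `O=C(Nn1c(-c2cccc([N+](=O)[O-])c2)nc2c(-c3ccc(F)cc3)n[nH]c2c1=O)c1cccnc1` — 28.8%

Of the compounds shown here, two of a shared core have been measured in a functional assay on A549 cells (Homo sapiens) for cytotoxicity, read by sulforhodamine B assay, with a stated time of 2 days, tested at 100 uM; a lower number here means less inhibition, a higher number more inhibition at the concentration tested (going by the name of the read-out). Compound 1 gives 19.7%, and compound 2 gives 28.8%. Going by the values given here, the single step between them, a number 9.1 percentage points higher from compound 1 to compound 2 (within the scatter), was a fluoro in place of chloro on an aromatic carbon, and it stays within the scatter. On the numbers shown compound 2 carries the larger of the two readings, but its only neighbour, compound 1, sits within the scatter of it, so nothing can be said about order.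

Compound 3 `O=C(Nn1c(-c2cccc([N+](=O)[O-])c2)nc2c(-c3ccco3)n[nH]c2c1=O)c1cccnc1` is not yet measured. Against compound 2 the difference is furan-2-yl in place of 4-fluorophenyl on an aromatic carbon. Among the compounds with values here, the one measured step bears on this only loosely: it exchanged one halogen for another on the same ring and moved nothing beyond the scatter, whereas here the ring itself is traded. Within the data shown here, no measured pair covers such an exchange, so no direction can be drawn from the data. Compound 3 is therefore expected to fall near compound 2, at an estimated 24% with a range from 5% to 45%. This expectation amounts to a step of a number 4.8 percentage points lower from compound 2 to compound 3 (within the scatter), within the scatter.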

Compound 3, a percentage reported as inhibition, at one concentration (the size of the read-out at that concentration, not a potency): 1.51%
The estimate for compound 3 lay 22.5 percentage points above the measured number, outside the stated range (below it).
By their numbers in this assay, from the lowest: compound 3; then compounds 1 and 2 (each within the scatter of the next).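

In this assay, going by these compounds alone, the exchange of the whole ring at this position, on an aromatic carbon of a five-membered aromatic ring with 2 nitrogen, gave the first steps beyond the scatter: a number 27.3 percentage points lower from compound 2 to compound 3 (beyond the scatter), and in the same way a number 18.2 percentage points lower from compound 1 to compound 3 (beyond the scatter). The halogen exchange between compound 1 and compound 2 had stayed within the scatter, so this position proved responsive in this assay only once the 4-halophenyl ring itself gave way to furan-2-yl. No measurement at hand bears on why the reading fell.

Furan-2-yl differs from 4-fluorophenyl in ring size, in its ring oxygen and in its hydrogen-bond acceptor all at once, and these compounds cannot separate those differences. Going by these compounds, it remains open how an unsubstituted phenyl, a thiophen-2-yl or a pyridin-3-yl would read at this position, and whether a small non-ring group such as a methyl or an amine would read like compound 3 or like the halogenated pair.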